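The compounds below may be only part of what the source reports. "The series", "measured", "known", "first", "only" and "open" are said of these compounds alone.

Measured compounds:

compound 1, `CCCCCCCC/C=C\CCCCCCCCO[C@H]1O[C@H](CO)[C@@H](O)[C@H](O)[C@H]1NC(C)=O`, 4.6 uM in a functional assay on U-373MG ATCC cells (Homo sapiens), read by thymidine incorporation; on this read-out lower numbers stand for stronger inhibition and higher numbers for weaker inhibition
compound 2, `CCCCCCCC/C=C\CCCCCCCC(=O)N[C@H]1[C@@H](OCCCCCCCC)O[C@H](CO)[C@@H](O)[C@@H]1O`, 13.3 uM in this assay
compound 3, `CCCCCCCC/C=C\CCCCCCCC(=O)N[C@H]1[C@@H](OCCCCCCCC)O[C@H](CO)[C@@H](O)[C@@H]1OS(=O)(=O)O`, 15.6 uM in this assay

Compound 1 gives the lowest number of the three; the difference between its core and the core of compound 2 is not broken down here. Within the core of compound 2, one change has been made: sulfo in place of hydrogen on an oxygen on a saturated carbon. It gave a 1.2-fold higher number from compound 2 to compound 3 (0.07 log units; within the scatter).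

Compound 4, `CCCCCCCC/C=C\CCCCCCCCO[C@H]1O[C@H](COS(=O)(=O)O)[C@@H](O)[C@H](O)[C@H]1NC(C)=O`, remains to be measured. It carries the same kind of change relative to compound 1: sulfo in place of hydrogen on an oxygen on a saturated carbon. The two places are not the same: in compound 4 the other neighbour of the carbon is a saturated chain carbon, in compound 3 a saturated ring carbon. Going by the values given here, with only one measured example of this kind of change, the expectation for compound 4 rests on that step: the estimated step is a 1.2-fold higher number from compound 1 to compound 4 (0.08 log units; within the scatter), essentially flat, because compound 3 moved only a 1.2-fold higher number from compound 2 to compound 3 (0.07 log units; within the scatter) from compound 2. Compound 4 is thus expected to give about 5.5 uM, with a likely range from 2.5 uM to 12 uM.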

Compound 4, concentration for 50% inhibition: 13 uM
Compound 4: the middle estimate sits 2.4-fold (0.37 log units) below what was measured; measured number above the stated range.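

In this assay, sulfo in place of hydrogen gave a 2.8-fold higher number from compound 1 to compound 4 (0.45 log units; beyond the scatter), a step beyond the scatter on its own. Set beside the earlier step, it cannot be told apart from it: the same change on two cores in this assay, a 1.2-fold higher number (0.07 log units; within the scatter) from compound 2 to compound 3 and a 2.8-fold higher number (0.45 log units; beyond the scatter) from compound 1 to compound 4, 2.4-fold (0.38 log units) apart, within the scatter of two such steps So no dependence on the core is shown, but neither is reliable transfer: there are only two steps, and the carbon's other neighbour is a saturated chain carbon in compound 4 and a saturated ring carbon in compound 3, so core and place remain confounded.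

The compounds shown leave open whether sulfo on a ring hydroxy of the core of compound 1 gives a step of similar size. Also open, from the compounds shown here alone, is whether a phosphate or a carboxylic acid in place of sulfo would behave alike.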